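The source may hold more compounds than are shown below. What is called first, only, known or untested is meant among the compounds shown, and "the series" means these compounds.

Compound 2 `Cc1ccc(-c2nc(C)c(COc3ccc4c(c3)OCC4CC(=O)O)s2)cc1` stands highest of the two numbers measured in a functional assay on CHO cells for agonist activity at Free fatty acid receptor 1 (Homo sapiens), read by FLIPR and calcium flux, tested at 100 nM (a lower number here means a weaker effect, a higher number a stronger effect of the compound at the concentration tested), where compound 2 gives 54.9%; compound 1 `Cc1nc(-c2cc3ccccc3o2)sc1COc1ccc2c(c1)OCC2CC(=O)O` gives 14.8%. Compound 3 `Cc1nc(-c2ccccc2C(F)(F)F)sc1COc1ccc2c(c1)OCC2CC(=O)O` differs from compound 2 by 2-(trifluoromethyl)phenyl in place of 4-methylphenyl on an aromatic carbon. Within the data shown here, the one measured step at this place, a number 40.1 percentage points higher from compound 1 to compound 2 (beyond the scatter), changed a different group, so it bears only loosely on the new change, and no step with a trifluoromethyl is known. The estimated step of a number 19.9 percentage points lower from compound 2 to compound 3 (beyond the scatter) is therefore modest and downward, with wide uncertainty. Compound 3 is expected to give about 35%, within a range from 5% to 70%.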

Compound 3, a percentage reported as activity, at one concentration (the size of the read-out at that concentration, not a potency): 7.76%
The estimate for compound 3 lay 27.2 percentage points above the measured number; measured number inside the range.
By their numbers in this assay, from the lowest: compounds 3 and 1 (each within the scatter of the next); then compound 2.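

In this assay, 2-(trifluoromethyl)phenyl in place of 4-methylphenyl brought a number 47.1 percentage points lower from compound 2 to compound 3 (beyond the scatter) at this place, so a phenyl ring here does not by itself keep the higher read-out. Set against 1-benzofuran-2-yl, the same group gave a number 7 percentage points lower from compound 1 to compound 3 (within the scatter) and the two groups stand level, leaving compound 2 alone apart. Nothing available explains these differences. On these data alone, whether the trifluoromethyl group itself or where it sits on the phenyl ring accounts for the step stays open, as does how an unsubstituted phenyl, or a phenyl carrying a methoxy group or an amine, would read at this place.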